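Replacing the amide of compound 3 with a fused-hydrogen-donor ring

A few compounds are considered here, and "the series" means these few. Any claim that something is new, unique, unknown or untested is made for them only; others in the source may bear on it.

Of the compounds shown here, three sharing one core have been measured in an assay (Rattus norvegicus) for inhibition of Fatty-acid amide hydrolase 1 (Homo sapiens); on this read-out lower numbers stand for stronger inhibition and higher numbers for weaker inhibition. Compound 1 `COc1ccccc1-c1cnc(C(=O)CCCCCCc2ccccc2)o1` gives 400 nM. Compound 2 `Nc1cccc(-c2cnc(C(=O)CCCCCCc3ccccc3)o2)c1` gives 19 nM, and compound 3 `O=C(CCCCCCc1ccccc1)c1ncc(C(=O)N2CCSCC2)o1` gives 10 nM. Compound 3 thus has the lowest number of the three, but its edge over compound 2 is only a 1.9-fold lower number from compound 2 to compound 3 (0.28 log units; within the scatter), which does not separate the two, whereas a 40-fold lower number from compound 1 to compound 3 (1.60 log units; beyond the scatter) is a clear gap.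

Compound 4 `O=C(CCCCCCc1ccccc1)c1ncc(-c2cc(=O)[nH]c(=O)[nH]2)o1` has not been measured. Its change from compound 3 is a group of 8 heavy atoms (4 carbon, 2 nitrogen, 2 oxygen; one six-membered aromatic ring with 2 hetero atoms) in place of a group of 8 heavy atoms (5 carbon, 1 nitrogen, 1 oxygen, 1 sulfur; one six-membered non-aromatic ring with 2 hetero atoms), on an aromatic carbon. The measured steps that touch this position are a 21-fold lower number from compound 1 to compound 2 (1.32 log units; beyond the scatter) and a 40-fold lower number from compound 1 to compound 3 (1.60 log units; beyond the scatter), both large, showing that the group on this carbon can move the number a long way. The step of a 1.9-fold lower number from compound 2 to compound 3 (0.28 log units; within the scatter) shows that two quite different groups can also land close together. Within the data shown here, no measured compound carries a six-membered aromatic ring with two hydrogen-bond donors here, so the direction is uncertain; a moderate weakening relative to compound 3 seems the more likely outcome, expected as a 3.5-fold higher number from compound 3 to compound 4 (0.54 log units; beyond the scatter).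

For compound 4 the value in this assay is estimated at 35 nM, with a range from 6 nM to 300 nM.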

Compound 4, inhibition constant: 12 nM
Compound 4: middle estimate off by 2.9-fold (0.46 log units), on the high side, within the range that was stated.
By their numbers in this assay, from the lowest: compounds 3, 4 and 2 (each within the scatter of the next); then compound 1.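

In this assay, the six-membered aromatic ring with 2 hetero atoms carries hydrogen-bond donors that the (thiomorpholin-4-yl)carbonyl group lacks, yet swapping one for the other gives a 1.2-fold higher number from compound 3 to compound 4 (0.08 log units; within the scatter) and so no readable difference. The comparison with the 3-aminophenyl group, a 1.6-fold lower number from compound 2 to compound 4 (0.20 log units; within the scatter), also stays inside the scatter, while the comparison with the 2-methoxyphenyl group, a 33-fold lower number from compound 1 to compound 4 (1.52 log units; beyond the scatter), remains a large one. This aromatic carbon next to the ring oxygen therefore tolerates a third quite different group without a clear loss, and among the four compounds only compound 1 stands apart from the others, which cannot be separated from one another.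

Nothing available explains why such different groups give such close numbers. On these data alone, it also stays open whether the hydrogen-bond donors of the new ring matter at all, and a carboxylic acid or an unsubstituted phenyl ring on this same carbon would give a further point of comparison with the shared core.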